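Aryl ether substitution in a fatty acid receptor agonist series

The compounds below may be only part of what the source reports. "The series", "measured", "known", "first", "only" and "open" are said of these compounds alone.

Measured compounds:
compound 1 `CC(Oc1ccccc1)C(=O)Nc1ccc(OCC(=O)O)c(F)c1`, 35.7%
compound 2 `CC(C)(Oc1ccccc1)C(=O)Nc1ccc(OCC(=O)O)c(F)c1`, 3.56%
compound 3 `CCOc1ccccc1OC(C)C(=O)Nc1ccc(OCC(=O)O)c(F)c1`, 8.79%

In a functional assay on CHO cells for agonist activity at Free fatty acid receptor 1 (Homo sapiens), read by FLIPR, tested at 100 nM (a higher number here means a stronger effect of the compound at the concentration tested, a lower number a weaker effect), compound 1 gives 35.7%, the highest of the three numbers. Compound 3 with 8.79% is nearest to it, and compound 2 with 3.56% furthest. Both changes made on the aryl ether side of compound 1 have lowered the read-out beyond the scatter: a number 32.1 percentage points lower from compound 1 to compound 2 (beyond the scatter), and a number 26.9 percentage points lower from compound 1 to compound 3 (beyond the scatter).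

Compound 4 `CC(Oc1cccc(C(F)(F)F)c1)C(=O)Nc1ccc(OCC(=O)O)c(F)c1` is not yet measured. It differs from compound 1 by trifluoromethyl in place of hydrogen on an aromatic carbon, meta to a large group. The step from compound 1 to compound 3 bears most directly on it, since that step also adds a group to an aromatic carbon of the same ring, and it was modest in size. The step from compound 1 to compound 2 shows that a methyl in this region likewise lowered the number, and by a large amount. Neither step puts the same group in the same place, so the direction is read from them only loosely. A decrease beyond the scatter is expected, smaller than either measured step. Compound 4 is expected to give 18%, with a range of 2% to 42%. For compound 4 this means an expected step of a number 17.7 percentage points lower from compound 1 to compound 4 (beyond the scatter).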

Compound 4, a percentage reported as activity, at one concentration (the size of the read-out at that concentration, not a potency): 12.7%
Beside the measured number, compound 4's estimate is 5.3 percentage points above it; low and high end bracket the measured number.
By their numbers in this assay, from the lowest: compounds 2, 3 and 4 (each within the scatter of the next); then compound 1.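

In this assay trifluoromethyl in place of hydrogen on an aromatic carbon, meta to a large group, gives a number 23 percentage points lower from compound 1 to compound 4 (beyond the scatter) and so extends the loss on this aromatic ring beyond the ethoxy group of compound 3. Across the four compounds, each single change to compound 1 lowers the number, whether it is ethoxy or trifluoromethyl on the ring or methyl on the chain carbon, and none goes against this pattern; compound 1 remains the highest, with all three of its steps beyond the scatter. The data give no measured basis for explaining the loss at this position, so the drop can only be recorded as an observation.

As far as these compounds go, whether a fluorine, a chlorine, a methyl or a methoxy group on the same aromatic carbon would hold the read-out nearer to that of compound 1 remains open, so the present result cannot separate an effect of this place on the ring from one specific to trifluoromethyl. The read-out also comes from a single concentration, which leaves the potency of all four compounds undefined.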